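This account rests on a few compounds, and the source may have more. Where it says the series, first, only, none or still open, it means among the compounds named here.

Compound 1 `Cc1ccccc1Nc1nc(NC2CCCCC2)ncc1Cl`: > 100000 nM, a limit
Compound 2 `Cc1ccc(Nc2ncc(Cl)c(Nc3ccccc3C)n2)cc1`: > 100000 nM, a limit
Compound 3 `Cc1ccccc1Nc1nc(Nc2ccccn2)ncc1Cl`: 20100 nM

In a functional assay on Jurkat cells (Homo sapiens) for inhibition, read by CCK-8 assay, with a stated time of 48 h (a higher number here means a weaker inhibitor of growth, a lower number a stronger inhibitor of growth), compound 2 stands at the limit of > 100000 nM in this assay, at which 2 of the 3 values shown sit. Compound 4 `Cc1ccccc1Nc1nc(Nc2cc(Cl)ccn2)ncc1Cl` carries 4-chloropyridin-2-yl in place of 4-methylphenyl on a nitrogen on an aromatic ring. The closest measured change puts pyridin-2-yl in place of 4-methylphenyl, giving an at least 4.9-fold lower number from compound 2 to compound 3 (0.69 log units; beyond the scatter). Pyridin-2-yl in place of cyclohexyl gave an at least 4.9-fold lower number from compound 1 to compound 3 (0.69 log units; beyond the scatter). Both steps are bounded by a limit at one end, and neither shows the effect of the added chlorine. With compound 3 at 20100 nM as the nearest guide, a lower number beyond the scatter is expected in this assay. The expected change is an at least 6.6-fold lower number from compound 2 to compound 4 (0.82 log units; beyond the scatter). For compound 4 the estimated value is 15000 nM, with an expected range of 4000 nM to 60000 nM.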

Compound 4, concentration for 50% growth inhibition: 39600 nM
The estimate for compound 4 lay 2.6-fold (0.42 log units) below the measured number; the measured number falls inside the stated range.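

In this assay, chloro in place of hydrogen on an aromatic carbon gives a 2.0-fold higher number from compound 3 to compound 4 (0.29 log units; within the scatter), so this added chlorine separates nothing beyond the scatter. The 4-chloropyridin-2-yl group still stands apart from 4-methylphenyl and from cyclohexyl on that nitrogen, with an at least 2.5-fold lower number from compound 2 to compound 4 (0.40 log units; beyond the scatter) and an at least 2.5-fold lower number from compound 1 to compound 4 (0.40 log units; beyond the scatter). Both of these steps start from a limit, so their full size cannot be read: the limit of > 100000 nM in this assay, at which 2 of the 4 values shown sit.

From the compounds shown here alone, it remains open whether a methoxy group or an amine in place of that chloro would move the number beyond the scatter, and whether a pyrimidin-2-yl group on that nitrogen would do so.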